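Hydroxy to bromo: an expectation at the assay limit

The source may hold more compounds than are shown below. What is called first, only, known or untested is meant among the compounds shown, and "the series" means these compounds.

Compound 1 `O=C(/C=C\c1ccc(O)cc1)N1N=C(c2ccncc2)OC1c1c[nH]c2ccccc12` is tested in an ADME assay on A549 cells (Homo sapiens) for cytotoxicity, read by MTT assay, with a stated time of 48 h; a higher number here means a weaker inhibitor of growth, a lower number a stronger inhibitor of growth. For compound 1 only a limit is known: it gives > 30 ug/mL, which is the limit of the assay rather than a number. Compound 2 `O=C(/C=C\c1ccc(Cl)cc1)N1N=C(c2ccncc2)OC1c1c[nH]c2ccccc12` likewise reaches only the limit of > 30 ug/mL. Compound 3 `O=C(/C=C\c1ccc(Cl)cc1Cl)N1N=C(c2ccncc2)OC1c1c[nH]c2ccccc12` also yields only a limit, > 30 ug/mL. All three values thus sit at the same point (the limit of > 30 ug/mL in this assay, at which 3 of the 3 values shown sit), and the steps among them cannot be read: a step that the two limits leave unreadable from compound 1 to compound 2, a step that the two limits leave unreadable from compound 1 to compound 3 and a step that the two limits leave unreadable from compound 2 to compound 3.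

Compound 4 `O=C(/C=C\c1ccc(Br)cc1)N1N=C(c2ccncc2)OC1c1c[nH]c2ccccc12` differs from compound 1 by the change (bromo in place of hydroxy on an aromatic carbon). The measured step that bears on this change is a step that the two limits leave unreadable from compound 1 to compound 2, chloro in place of hydroxy on an aromatic carbon; its size is hidden by the two limits. Among the measured compounds shown here, since every value so far rests at the limit (the limit of > 30 ug/mL in this assay, at which 3 of the 3 values shown sit), compound 4 is expected to remain near it, with an expected step that the limit leaves unreadable from compound 1 to compound 4. The estimate for compound 4 in this assay is 40 ug/mL, within a range from 20 ug/mL to 100 ug/mL.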

Compound 4, concentration for 50% growth inhibition: > 30 ug/mL
Compound 4: no number, only a limit; the forecaster's own chance of this, stated with the estimate: 75%; the middle value lies beyond the limit too.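

In this assay compound 4 gives > 30 ug/mL, a limit of the assay and not a number. Its steps to compound 1, compound 2 and compound 3 therefore cannot be read: the limit of > 30 ug/mL in this assay, at which 4 of the 4 values shown sit. The compounds shown leave open whether hydroxy, chloro and bromo differ at all in this assay.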